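Swapping an amide for a sulfonamide on a shared core

The compounds below may be only part of what the source reports. "The series", "measured", "known", "first", "only" and "open" are said of these compounds alone.

Compound 1, `CC(=O)N[C@@H]1CCCc2c1cncc2N1CCc2cc(Cl)ccc2C1=O`, gives 3920 nM in an ADME assay on cells for inhibition of cytochrome P450 11B1, mitochondrial (Homo sapiens), read by HTRF; on this read-out lower numbers stand for stronger inhibition and higher numbers for weaker inhibition.
Compound 3, `CCC(=O)N[C@@H]1CCCc2c1cncc2N1CCc2cc(Cl)ccc2C1=O`, gives 3330 nM in this assay.
Compound 2, `O=C(Nc1cccnc1)c1ccc(Cl)cc1F`, gives only a limit in this assay, > 3000 nM, and this is the limit of > 3000 nM in this assay, at which 1 of the 3 values shown sits.

Among the two numbers shown, compound 3 has the lower one, and the nearest value belongs to compound 1. The step of a 1.2-fold lower number from compound 1 to compound 3 (0.07 log units; within the scatter) is within the scatter, so the two cannot be ordered.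

Compound 4, `CS(=O)(=O)N[C@@H]1CCCc2c1cncc2N1CCc2cc(Cl)ccc2C1=O`, has not yet been measured in this assay. It differs from compound 3 by methylsulfonyl in place of propanoyl on an amine nitrogen. Among the compounds with values here, the only measured step that touches this part of the molecule is the one from compound 1 to compound 3, which lengthened the chain on the carbonyl carbon by one carbon and stayed within the scatter. That step leaves the carbonyl in place, whereas here the carbonyl gives way to a sulfonyl, so it bears on the change only loosely. Within the data shown here, no step that replaces the carbonyl itself has been measured, and nothing among the measured results speaks to the sulfonyl.

On this basis the step of a 1.2-fold higher number from compound 3 to compound 4 (0.08 log units; within the scatter) is expected to stay within the scatter, with no direction favoured. Compound 4 is therefore estimated at 4000 nM, in the range from 1500 nM to 12000 nM in this assay.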

Compound 4, half-maximal inhibitory concentration: 5150 nM
For compound 4 the middle estimate is 1.3-fold (0.11 log units) below the measured one, and the stated range covers the measured number.
By their numbers in this assay, from the lowest: compounds 3, 1 and 4 (each within the scatter of the next).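

Putting methylsulfonyl in place of propanoyl on this amine nitrogen gives a 1.5-fold higher number from compound 3 to compound 4 (0.19 log units; within the scatter) in this assay, and putting it in place of acetyl gives a 1.3-fold higher number from compound 1 to compound 4 (0.12 log units; within the scatter) in the same read-out. The earlier pair varied only the length of the chain on a carbonyl that stayed in place, whereas here the carbonyl itself gives way to a sulfonyl, and the values of compound 1, compound 3 and compound 4 still cannot be ordered, so on these three compounds alone this position tolerates an amide or a sulfonamide with no difference that can be read. No measured result shown here bears on why the amide and the sulfonamide cannot be told apart.

What the compounds shown leave open is whether any group on this nitrogen can move the number beyond the scatter at all, since all three carry a small acyl or sulfonyl group. The free amine, a urea, or a longer chain on the sulfonyl such as ethylsulfonyl or phenylsulfonyl would each test this position further, on the same shared core.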